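Removing a Ring Methyl from the Piperidine Side Chain

The source may hold more compounds than are shown below. What is called first, only, known or untested is meant among the compounds shown, and "the series" means these compounds.

Compound 1 `COc1cc2c(Nc3nc4ccc(C(=O)Nc5c(C)cc(C)cc5C)cc4s3)ncnc2cc1OCCCN1CCC(C)CC1` gives 5600 nM in a functional assay on U-937 cells (Homo sapiens) for cytotoxicity, read by WST assay, with a stated time of 72 h (on this read-out higher numbers stand for weaker inhibition and lower numbers for stronger inhibition), the lowest of the three numbers recorded; compound 2 `COc1cc2c(Nc3nc4ccc(C(=O)Nc5c(C)cccc5C)cc4s3)ncnc2cc1OCCCN1CCC(C)CC1` gives 11200 nM and compound 3 `COc1cc2c(Nc3nc4ccc(C(=O)Nc5c(C)cccc5Cl)cc4s3)ncnc2cc1OCCCN1CCC(C)CC1` gives 9200 nM, and both steps, a 2.0-fold higher number from compound 1 to compound 2 (0.30 log units; within the scatter) and a 1.6-fold higher number from compound 1 to compound 3 (0.22 log units; within the scatter), are within the scatter. Compound 4 `COc1cc2c(Nc3nc4ccc(C(=O)Nc5c(C)cc(C)cc5C)cc4s3)ncnc2cc1OCCCN1CCCCC1` differs from compound 1 by hydrogen in place of methyl on a saturated ring carbon. Within the data shown here, no measured step touches this saturated ring; the only comparable removal of a methyl is a 2.0-fold higher number from compound 1 to compound 2 (0.30 log units; within the scatter), on an aromatic carbon and within the scatter. He therefore expects no step beyond the scatter, a 1.2-fold higher number from compound 1 to compound 4 (0.06 log units; within the scatter), and estimates compound 4 at 6500 nM, between 2500 nM and 17000 nM.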

Compound 4, half-maximal inhibitory concentration: 12200 nM
Estimate against measurement, compound 4: 1.9-fold (0.27 log units) below; the measured number falls inside the stated range.
By their numbers in this assay, from the lowest: compounds 1, 3, 2 and 4 (each within the scatter of the next, the first and the last beyond it).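

Going from 4-methylpiperidin-1-yl to piperidin-1-yl gives, in this assay, a 2.2-fold higher number from compound 1 to compound 4 (0.34 log units; beyond the scatter), a modest step but the first in this set beyond the scatter. The earlier steps shown here, all on the aromatic group of the amide, stayed within it, so the methyl on the saturated ring carbon is the one place here where a change registers. Nothing measured here gives a reason for this step.

Going by these compounds, whether an ethyl or a hydroxyl on that ring carbon, or a morpholine in place of the piperidine, would shift the number remains open. So does whether removing this methyl gives a similar step with the 2-chloro-6-methylphenyl amide of compound 3.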